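The source may report more compounds than this note shows. Statements on the series, on what has been measured and on what is new or still open speak of the compounds shown alone.

Among the measured compounds shown here, in a functional assay on COLO 205 cells (Homo sapiens) for inhibition, read by sulforhodamine B assay, with a stated time of 48 h, tested at 50 uM (on this read-out lower numbers stand for less inhibition of growth and higher numbers for more inhibition of growth at the one concentration tested), compound 1 `COc1cc(/C=C/C(=O)/C=C/c2cccc3ccccc23)ccc1OCc1cn(CCCCOc2cc(=O)oc3ccccc23)nn1` gives 50% and compound 2 `COc1cc(/C=C/C(=O)/C=C/c2cccs2)ccc1OCc1cn(CCCCOc2cc(=O)oc3ccccc23)nn1` gives 40%, the only two numbers so far. For the measured compounds named here, these two values lie within the usual scatter of repeated measurements, so compound 2 cannot yet be placed apart from its single neighbour. Going by the values given here, the next molecule, compound 3 `COc1ccc(/C=C/C(=O)/C=C/c2ccc(OCc3cn(CCCCOc4cc(=O)oc5ccccc45)nn3)c(OC)c2)cc1`, has no measurement yet. It keeps the rest of compound 2 and swaps one group on a double-bonded chain carbon bound to a double-bonded chain carbon, and the change is 4-methoxyphenyl in place of thiophen-2-yl on a double-bonded chain carbon bound to a double-bonded chain carbon. Among the compounds with values here, only one measured step touches this same place, and it reads a number 10 percentage points lower from compound 1 to compound 2 (within the scatter). Within the data shown here, no measured compound carries 4-methoxyphenyl, so the guess rests on that single step, which stayed small. No clear shift is therefore expected from this swap, in either direction. The estimated step is a number 5 percentage points higher from compound 2 to compound 3 (within the scatter) and is expected to stay within the scatter. For compound 3 the expected value is 45%, with an estimated range from 30% to 60%.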

Compound 3, percent growth inhibition at one concentration: 49%
The estimate for compound 3 lay 4 percentage points below the measured number; the measured number falls inside the stated range.
By their numbers in this assay, from the lowest: compounds 2, 3 and 1 (each within the scatter of the next).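

In this assay, the place on a double-bonded chain carbon bound to a double-bonded chain carbon now has three different ring groups to compare: 4-methoxyphenyl in place of thiophen-2-yl gives a number 9 percentage points higher from compound 2 to compound 3 (within the scatter), and 4-methoxyphenyl in place of naphthalen-1-yl gives a number 1 percentage points lower from compound 1 to compound 3 (within the scatter). Among the compounds shown here, earlier, only one step at this place could be read; now all three compounds lie within the scatter of one another, including compound 3, whose six-membered carbon ring carries a methoxy group, so at this one concentration the assay does not separate these three ring groups. Nothing measured here accounts for why the three groups read alike.

On these data alone, all three groups at this place are aromatic rings, so it remains open whether a group of another kind, such as a dimethylamino-substituted phenyl ring, a carboxylic acid or a plain alkyl chain, would move the number beyond the scatter. As far as these compounds go, with a single concentration and a single cell line, it also remains open whether these three compounds would still read alike at other concentrations or on other cells.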